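Adding a nitro group to the phenyl end of compound 1

A few compounds are considered here, and "the series" means these few. Any claim that something is new, unique, unknown or untested is made for them only; others in the source may bear on it.

For the measured compounds named here, in an ADME assay on HEL cells (Homo sapiens), read by cell counting, with a stated time of 3 days (a higher number here means that more compound is tolerated, a lower number that less compound is tolerated), compound 1 (`O=c1[nH]c(=O)n([C@H]2C[C@H](O)[C@@H](CO)O2)cc1C#CC#Cc1ccccc1`) gives 100000 nM, the higher of the two exact numbers so far. Compound 2 (`CCCCCCc1ccc(C#CC#Cc2cn([C@H]3C[C@H](O)[C@@H](CO)O3)c(=O)[nH]c2=O)cc1`) gives 35000 nM. Compound 3 (`Nc1cccc(C#CC#Cc2cn([C@H]3C[C@H](O)[C@@H](CO)O3)c(=O)[nH]c2=O)c1`) gives > 100000 nM, which is a limit of the assay and not a number.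

Compound 4 (`O=c1[nH]c(=O)n([C@H]2C[C@H](O)[C@@H](CO)O2)cc1C#CC#Cc1ccc([N+](=O)[O-])cc1`) has nitro in place of hydrogen on an aromatic carbon, para to a large group (nitro in place of hydrogen on an aromatic carbon). Going by the values given here, two measured steps bear on this change, though neither involves nitro. Hexyl in place of hydrogen on an aromatic carbon gave a 2.9-fold lower number from compound 1 to compound 2 (0.46 log units; beyond the scatter), a modest drop. Amino in the same kind of exchange gave a number no lower from compound 1 to compound 3 (the limit leaves the size open), whose size stays open. Compound 2 at 35000 nM therefore marks the only measured drop, so a small downward step is expected, or none beyond the scatter. The estimated step is a 1.7-fold lower number from compound 1 to compound 4 (0.22 log units; within the scatter). Compound 4 is estimated at 60000 nM, with an expected range from 20000 nM to 100000 nM.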

Compound 4, half-maximal cytotoxic concentration: 89000 nM
Beside the measured number, compound 4's estimate is 1.5-fold (0.17 log units) below it; the measured number falls inside the stated range.
By their numbers in this assay, from the lowest: compound 2; then compounds 4 and 1 (each within the scatter of the next).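

In this assay nitro in place of hydrogen on the aromatic carbon para to a large group gives a 1.1-fold lower number from compound 1 to compound 4 (0.05 log units; within the scatter) and so stays within the scatter. Nitro in place of hexyl at the same place gives a 2.5-fold higher number from compound 2 to compound 4 (0.41 log units; beyond the scatter) and shows that the drop seen with hexyl does not come with every group put there. Compound 3 stands at a limit and not at a number: the limit of > 100000 nM in this assay, at which 1 of the 4 values shown sits.
The step to compound 4 reads an at least 1.1-fold lower number from compound 3 to compound 4 (0.05 log units; that floor lies within the scatter) and so gives only a floor and not a size.

The compounds shown leave open whether a shorter chain such as butyl at this position already brings a drop beyond the scatter. They also leave open what a carboxylic acid would do there.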